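Carbocyclic ring in place of the hydroxybutyl chain

A few compounds are considered here, and "the series" means these few. Any claim that something is new, unique, unknown or untested is made for them only; others in the source may bear on it.

Measured so far:
compound 1 `C=CCn1c(=O)n(CCCCO)c2nc(N)nc(O)c21`: 16%
compound 2 `CCCCn1c(=O)n(C2OC(CO)[C@@H](O)[C@H]2O)c2nc(N)nc(O)c21`: 70%
compound 3 `C=CCn1c(=[Se])n(C2OC(CO)[C@@H](O)[C@H]2O)c2nc(N)nc(O)c21`: 107%

In a functional assay on the whole organism with Mus musculus as the target (a lower number here means a smaller maximal response, a higher number a larger maximal response), compound 1 gives the lowest of the three numbers. The nearest of the others is compound 2, whose value lies well beyond the scatter above it; compound 3 stands further off still, again beyond the scatter. Both of the higher compounds carry a ring on the aromatic nitrogen where compound 1 carries an open chain.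

Compound 4 `C=CCn1c(=O)n(C2CCC(CO)C2)c2nc(N)nc(O)c21` has not yet been measured in this assay. It departs from compound 1 at that same position: a group of 7 heavy atoms (6 carbon, 1 oxygen; one five-membered non-aromatic ring of carbon only) in place of a group of 5 heavy atoms (4 carbon, 1 oxygen; no ring), on an aromatic nitrogen

Going by the values given here, no measured pair shows this exact change, so the step has to be judged from what the three values show. Since both compounds that carry a ring at this nitrogen give the higher numbers, an upward step beyond the scatter is expected, though with wide uncertainty, as neither ring is the same as the one entering here. The step from compound 1 to compound 4 is estimated at a number 34 percentage points higher from compound 1 to compound 4 (beyond the scatter). For compound 4 the expected value is 50%, within a range of 20% to 85%.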

Compound 4, largest response reached (reported as maximal response), in percent of the reference or control that the assay uses: 0%
Compound 4: middle estimate off by 50 percentage points, on the high side; the whole stated range lies above it.
By their numbers in this assay, from the lowest: compound 4; then compound 1; then compound 2; then compound 3.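

On the aromatic nitrogen, the five-membered ring of carbon only in place of 4-hydroxybutyl gives, in this assay, a number 16 percentage points lower from compound 1 to compound 4 (beyond the scatter), and compound 4 stands at 0%. A ring at this position therefore does not by itself go with a larger maximal response: compound 4 goes against the link suggested by compound 2 and compound 3, although both of those also differ from compound 4 in other places. No independent data bear on why this change lowers the response.

Going by these compounds, it remains open whether a longer chain such as 6-hydroxyhexyl, or a carboxylic acid in place of the hydroxyl group, would change the response at this nitrogen. The separate contributions of the ring in compound 2 and compound 3, of the butyl group and of the selenium also remain unresolved.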